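A few compounds are considered here, and "the series" means these few. Any claim that something is new, unique, unknown or untested is made for them only; others in the source may bear on it.

Measured so far:
Compound 1, `COc1ccc(-n2nc(C(N)=O)cc2-c2cccc(OC(=O)NC3CCCCC3)c2)cc1`: in an assay on isolated protein for inhibition of Fatty-acid amide hydrolase 1 (Homo sapiens), read by fluorescence, with a stated time of 30 min (on this read-out lower numbers stand for stronger inhibition and higher numbers for weaker inhibition), compound 1 gives 743 nM.
Compound 2, `Cn1nc(C(N)=O)cc1-c1ccc(OC(=O)NC2CCCCC2)cc1`: in this assay compound 2 gives 209 nM.

Compound 2 holds the lowest number of the two, and its gap to compound 1 is beyond the scatter. Compound 1 differs from compound 2 in more than one place, so its value only shows that an aromatic group on the ring nitrogen, together with its other change, still gives measurable inhibition.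

Compound 3, `NC(=O)c1cc(-c2ccc(OC(=O)NC3CCCCC3)cc2)n(-c2ccc(Cl)cc2)n1`, has not yet been measured. It differs from compound 2 by 4-chlorophenyl in place of methyl on an aromatic nitrogen. For the measured compounds named here, no measured pair isolates this change. With only compound 1 as a loose guide, the step from compound 2 to compound 3 is expected to be small, at most a modest move toward a higher number, and likely within the scatter. Compound 3 is therefore estimated at 300 nM, within a range from 80 nM to 1200 nM, which means an expected step of a 1.4-fold higher number from compound 2 to compound 3 (0.16 log units; within the scatter).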

Compound 3, half-maximal inhibitory concentration: 172 nM
Estimate against measurement, compound 3: 1.7-fold (0.24 log units) above, and the stated range covers the measured number.
By their numbers in this assay, from the lowest: compounds 3 and 2 (each within the scatter of the next); then compound 1.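

In this assay the swap of methyl for 4-chlorophenyl on the aromatic nitrogen gives a 1.2-fold lower number from compound 2 to compound 3 (0.08 log units; within the scatter) and so leaves inhibition unchanged within the scatter. For the compounds shown here, this is the first reading that isolates this position: a much larger group, carrying a six-membered aromatic ring of carbon only, can sit here without a measurable loss, which compound 1 could not show, as it differs from compound 2 in more than one place. No measured information explains why the two groups read alike.

Going by these compounds, only these two groups have been compared directly at this nitrogen, so it remains open whether the same holds for an unsubstituted phenyl, a longer alkyl chain or a group carrying a carboxylic acid or an amine. On these data alone, whether any group here can move the number beyond the scatter also remains unknown.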